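The source may report more compounds than this note shows. Statements on the series, on what has been measured and on what is new or still open speak of the compounds shown alone.

Compound 1 `O=c1[nH]cnc2c1c(-c1ccsc1)cn2[C@@H]1O[C@H](CO)[C@@H](O)[C@H]1O`: > 15000 nM
Compound 2 `Cc1nc(N)c2c(-c3ccco3)cn([C@@H]3O[C@H](CO)[C@@H](O)[C@H]3O)c2n1`: > 20000 nM

Both readings in a functional assay on HepG2 cells (Homo sapiens) for antiproliferative activity, read by XTT assay, with a stated time of 72 h (a lower number here means a stronger inhibitor, a higher number a weaker inhibitor), are limits of the assay rather than numbers. For compound 1 the reading sits at the limit (the limit of > 15000 nM in this assay, at which 1 of the 2 values shown sits). For compound 2 the reading sits at the limit (the limit of > 20000 nM in this assay, at which 1 of the 2 values shown sits). On the numbers shown, compound 2 therefore stands only as a limit, and no order between it and compound 1 can be drawn. Among the compounds with values here, no step between measured compounds is available, since the two differ in more than one place.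

Compound 3 `Cc1nc(N)c2c(-c3cc4ccccc4o3)cn([C@@H]3O[C@H](CO)[C@@H](O)[C@H]3O)c2n1` differs from compound 2 in one place: 1-benzofuran-2-yl in place of furan-2-yl on an aromatic carbon. Nothing measured bears on this kind of change, so the expected step from compound 2 to compound 3 in this assay is an at least 1.1-fold lower number from compound 2 to compound 3 (0.04 log units; that floor lies within the scatter), most likely none beyond the scatter, and the reading may well remain a limit. Compound 3 is estimated at 18000 nM in this assay, within 4000 nM to 60000 nM.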

Compound 3, half-maximal inhibitory concentration: > 20000 nM
Compound 3 gave a limit, no number (the forecaster's own chance of this, stated with the estimate: 65%); at least 1.1-fold (0.04 log units) between middle value and limit.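

Compound 2 and compound 3 both stand as limits in this assay, so no step between them can be read: the limit of > 20000 nM in this assay, at which 2 of the 3 values shown sit.

The compounds shown leave open whether 1-benzofuran-2-yl in place of furan-2-yl on this aromatic carbon changes the antiproliferative reading at all.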